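Swapping the Ethyl for an Aryl on the Ring Nitrogen

A few compounds are considered here, and "the series" means these few. Any claim that something is new, unique, unknown or untested is made for them only; others in the source may bear on it.

Compound 1, `COc1ccc(C)cc1N1C(=O)CSC1c1cccc(C(=O)NCCCCc2ccccc2)c1`: 300 nM
Compound 2, `O=C(NCCCCc1ccccc1)c1cccc(C2SCC(=O)N2c2cccc(F)c2)c1`: 32.4 nM
Compound 3, `CCN1C(=O)CSC1c1cccc(C(=O)NCCCCc2ccccc2)c1`: > 1000 nM

These three compounds share one core and differ only in the group on an amide-type nitrogen in a ring. In a functional assay on HOS-TE85 cells (Homo sapiens) for inhibition, read by CCK-8 assay, with a stated time of 72 h (a higher number here means a weaker inhibitor, a lower number a stronger inhibitor), compound 1 gives 300 nM and compound 2 gives 32.4 nM. For compound 3, which carries an ethyl in that place, only a limit is known, (the limit of > 1000 nM in this assay, at which 1 of the 3 values shown sits), so compound 3 stands at the weak end of the set. The change to compound 4, `COc1ccc(F)cc1N1C(=O)CSC1c1cccc(C(=O)NCCCCc2ccccc2)c1`, is 5-fluoro-2-methoxyphenyl in place of ethyl on an amide-type nitrogen in a ring. Among the measured compounds shown here, two measured steps bear on this, both ending at compound 3: an at least 3.3-fold higher number from compound 1 to compound 3 (0.52 log units; beyond the scatter) and an at least 30-fold higher number from compound 2 to compound 3 (1.48 log units; beyond the scatter). Going the other way, from ethyl back to an aryl group, should therefore lower the number in this assay by a modest to large step. Compound 4 is expected to give about 150 nM, with a likely range from 40 nM to 600 nM. The expected step is an at least 6.6-fold lower number from compound 3 to compound 4 (0.82 log units; beyond the scatter).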

Compound 4, half-maximal inhibitory concentration: 8.8 nM
The estimate for compound 4 lay 17-fold (1.23 log units) above the measured number; measured number below the stated range.
By their numbers in this assay, from the lowest: compound 4; then compound 2; then compound 1. At a limit, above all of these: compound 3.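

Compound 3 is held only by a limit of the assay, not a number: the limit of > 1000 nM in this assay, at which 1 of the 4 values shown sits. Even so, in this assay, 5-fluoro-2-methoxyphenyl on the amide-type nitrogen in a ring gives a far larger gain over ethyl than the earlier aryl groups showed, with an at least 110-fold lower number from compound 3 to compound 4 (2.05 log units; beyond the scatter). The groups on the aryl ring also count, not just the presence of an aryl ring: fluoro in place of methyl gives a 34-fold lower number from compound 1 to compound 4 (1.53 log units; beyond the scatter), and methoxy in place of hydrogen gives a 3.7-fold lower number from compound 2 to compound 4 (0.57 log units; beyond the scatter).

Still open, going by these compounds, is whether chloro or trifluoromethyl could stand in for the fluoro, or ethoxy or hydroxy for the methoxy. Also open, on these data alone, is how a benzyl group or a pyridine ring would fare on that same nitrogen.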